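The source may report more compounds than this note shows. Statements on the series, on what has been measured and on what is new or still open speak of the compounds shown alone.

Compound 1 `COc1cc(NC(C)CCCNC(=O)Nc2cccc(Cl)c2)c2ncccc2c1` is the reference point of this small set. Going by the values given here, in a functional assay on HeLa cells (Homo sapiens) for inhibition, read by MTT assay, with a stated time of 72 h (a higher number here means a weaker inhibitor, a lower number a stronger inhibitor), compound 1 gives 17000 nM, the lowest of the three numbers measured so far. Compound 3 `COc1cc(NC(C)CCCNC(=O)Nc2cccc(O)c2)c2ncccc2c1` gives 48000 nM in this assay, and compound 2 `COc1cc(NC(C)CCCNC(=O)NNC(=O)Nc2ccc(Cl)cc2)c2ncccc2c1` gives 120000 nM in this assay. The measured steps read a 2.8-fold higher number from compound 1 to compound 3 (0.45 log units; beyond the scatter) and a 7.1-fold higher number from compound 1 to compound 2 (0.85 log units; beyond the scatter); between the other two, a 2.5-fold lower number from compound 2 to compound 3 (0.40 log units; beyond the scatter).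

Compound 4 `COc1cc(NC(C)CCCNC(=O)Nc2cccc(C(F)(F)F)c2)c2ncccc2c1` has not yet been measured. It differs from compound 1 by trifluoromethyl in place of chloro on an aromatic carbon. Among the compounds with values here, the only measured step at this same aromatic carbon, a 2.8-fold higher number from compound 1 to compound 3 (0.45 log units; beyond the scatter), shows a modest loss, but no measured pair exchanges chloro for trifluoromethyl, so the direction for compound 4 is not fixed by the data. Compound 4 is therefore expected to show a step of a 1.1-fold lower number from compound 1 to compound 4 (0.05 log units; within the scatter), within the usual scatter. The estimate for compound 4 in this assay is 15000 nM, with a range from 6000 nM to 40000 nM.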

Compound 4, half-maximal inhibitory concentration: 14000 nM
For compound 4 the middle estimate is 1.1-fold (0.03 log units) above the measured one; low and high end bracket the measured number.
By their numbers in this assay, from the lowest: compounds 4 and 1 (each within the scatter of the next); then compound 3; then compound 2.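

At this aromatic carbon, trifluoromethyl can stand in place of chloro in this assay without a change beyond the scatter (a 1.2-fold lower number from compound 1 to compound 4 (0.08 log units; within the scatter)), even though it brings more heavy atoms to the same place. The loss seen earlier with hydroxy therefore does not extend to every replacement of chloro here: trifluoromethyl in place of hydroxy gives a modest gain (a 3.4-fold lower number from compound 3 to compound 4 (0.54 log units; beyond the scatter)), and 3-(trifluoromethyl)phenyl in place of the ((4-chlorophenyl)carbamoyl)amino group on the amide-type nitrogen gives a somewhat larger one (an 8.6-fold lower number from compound 2 to compound 4 (0.93 log units; beyond the scatter)).

No measurement shown here accounts for these differences. The compounds shown leave open how an amine, a carboxylic acid or a nitrile at this aromatic carbon would compare with chloro and trifluoromethyl, and whether a longer chain in the linker would alter the picture.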